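Does a cyclopropyl group change compound 2's half-life?

This account rests on a few compounds, and the source may have more. Where it says the series, first, only, none or still open, it means among the compounds named here.

compound 1 `COc1ccc2cc1[C@@H](C)CN(C)C(=O)Nc1ccc(S(=O)(=O)C3CC3)c(c1)CN(C)C(=O)[C@@H]2Nc1ccc2c(N)ncc(F)c2c1`: 0.0667 h
compound 2 `CN1Cc2cc(ccc2S(=O)(=O)C2CC2)NC(=O)CCc2cccc(c2)[C@@H](Nc2ccc3c(N)ncc(F)c3c2)C1=O`: 0.217 h
compound 3 `COc1cc2cc(c1)[C@@H](Nc1ccc3c(N)ncc(F)c3c1)C(=O)N(C)Cc1cc(ccc1S(=O)(=O)C1CC1)NC(=O)CC2`: 0.25 h

These numbers come from an ADME assay on liver (Homo sapiens) for metabolic stability, using microsomes; a higher number here means that the compound lasts longer, a lower number that the compound disappears faster. Compound 2, at 0.217 h, lies within the usual scatter of compound 3, while compound 1 gives a lower number, 0.0667 h. Compound 2 therefore sits in the upper part of this small set, level with compound 3.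

The next compound is compound 4 `CN1Cc2cc(ccc2S(=O)(=O)C2CC2)NC(=O)CCc2cc(ccc2C2CC2)[C@@H](Nc2ccc3c(N)ncc(F)c3c2)C1=O`, which has not been measured yet. It differs from compound 2 by a single change: cyclopropyl in place of hydrogen on an aromatic carbon. In words, this is cyclopropyl in place of hydrogen on an aromatic carbon.

Among the compounds with values here, only one measured step replaces a hydrogen on an aromatic carbon with another group. That step is methoxy in place of hydrogen on an aromatic carbon, a 1.2-fold higher number from compound 2 to compound 3 (0.06 log units; within the scatter). It is small and stays inside the scatter, but it brings in a different group, so it is only a weak guide. Within the data shown here, no measured compound carries cyclopropyl. Compound 1 differs from compound 2 in more than one place, so it offers no clean comparison.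

No step beyond the scatter is therefore expected in this assay, and no clear direction is favoured. The expected step is a 1.1-fold lower number from compound 2 to compound 4 (0.04 log units; within the scatter). For compound 4 the estimated half-life is 0.2 h, with an expected range from 0.09 h to 0.4 h.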

Compound 4, half-life: 0.433 h
Compound 4: middle estimate off by 2.2-fold (0.34 log units), on the low side; the whole stated range lies below it.
By their numbers in this assay, from the lowest: compound 1; then compounds 2, 3 and 4 (each within the scatter of the next).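

In this assay, cyclopropyl in place of hydrogen on this aromatic carbon, ortho to a fused ring and para to a fused ring, gives a 2.0-fold higher number from compound 2 to compound 4 (0.30 log units; within the scatter) and so stays within the normal variation between repeat measurements. Within the data shown here, none of the earlier compounds carried cyclopropyl, so this is the first sign that this carbon can hold a three-membered carbon ring with no loss of half-life. The result falls short of a proven gain, however: compound 2 and compound 4 cannot be ranked on these numbers, and a clear improvement at this position remains to be shown.

A methyl, an isopropyl or a longer chain on the same aromatic carbon would help show whether the size or the shape of the added group matters for how long these compounds last. Nothing available here explains the step or shows which part of compound 4 is lost in the liver microsomes.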